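The source may hold more compounds than are shown below. What is called first, only, known or untested is meant among the compounds shown, and "the series" means these compounds.

Two analogues that share one core have so far been measured in a functional assay on YAC-1 cells (Mus musculus) for activation; a higher number here means that more compound is needed for the effect, a lower number that less compound is needed. Compound 1, `C=CCn1c(=O)n(C2CN(C(c3ccccc3)c3ccccc3)CC(CO)O2)c2nc(N)nc(O)c21`, gives 12 uM in this assay. Compound 2, `Nc1nc(O)c2c(n1)n(C1OC(CO)[C@@H](O)[C@H]1O)c(=O)n2Cc1ccc(Cl)c(Cl)c1`, gives 110 uM in this assay, the higher of the two numbers and well beyond the scatter away from compound 1; the two compounds differ in more than one place, so this gap is not read as a single step. Compound 3, `Nc1nc(O)c2c(n1)n(C1OC(CO)[C@@H](O)[C@H]1O)c(=O)n2Cc1ccc(Cl)cc1`, has not yet been measured. It differs from compound 2 in one place: hydrogen in place of chloro on an aromatic carbon, so the 3,4-dichlorobenzyl of compound 2 becomes a 4-chlorobenzyl. For the measured compounds named here, no measured pair shows this change, so the expectation rests on the value of compound 2 alone. A step of a 1.5-fold higher number from compound 2 to compound 3 (0.16 log units; within the scatter) is expected, small and toward a higher number, at most just beyond the scatter. Compound 3 is therefore estimated to give 160 uM in this assay, within a range from 50 uM to 500 uM.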

Compound 3, concentration for half-maximal effect: 180 uM
Compound 3: the middle estimate sits 1.1-fold (0.05 log units) below what was measured; measured number inside the range.
By their numbers in this assay, from the lowest: compound 1; then compounds 2 and 3 (each within the scatter of the next).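

For the compounds shown here, this is the first comparison that isolates a single place: with hydrogen in place of chloro on an aromatic carbon, turning the 3,4-dichlorobenzyl into a 4-chlorobenzyl, this assay gives a 1.6-fold higher number from compound 2 to compound 3 (0.21 log units; within the scatter). At this position, ortho to a chloro group and meta to a large group, the chloro can therefore be exchanged for hydrogen without a difference that can be told from the scatter. Nothing at hand explains this result or links it to any property of the chloro group.

The compounds shown leave open whether a methoxy group, an amine or a carboxylic acid at this position would read the same, and what an unsubstituted benzyl would give. They also leave open which of the several differences separates compound 1 from compound 2.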